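This account rests on a few compounds, and the source may have more. Where it says the series, first, only, none or still open, it means among the compounds named here.

In a functional assay on MCF7 cells (Homo sapiens) for antiproliferative activity, read by sulforhodamine B assay, with a stated time of 72 h (a higher number here means a weaker inhibitor, a lower number a stronger inhibitor), compound 1 `FC(F)(F)c1ccc(/C=C\c2cc3ccccc3nc2Cl)cc1` gives 4260 nM, and compound 2 `COc1ccc2nc(Cl)c(/C=C\c3ccc(C(F)(F)F)cc3)cc2c1` gives 12400 nM. Compound 2 therefore has the higher of the two numbers and is the weaker inhibitor of this pair. Going by the values given here, the only measured comparison is a 2.9-fold higher number from compound 1 to compound 2 (0.46 log units; beyond the scatter), a modest loss that accompanies methoxy in place of hydrogen on an aromatic carbon.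

Compound 3 `COc1ccc2nc(Cl)c(/C=C/c3ccc(C(F)(F)F)cc3)cc2c1` keeps the methoxy group and all other atoms and bonds of compound 2, and the structural change is confined to configuration: the two compounds have the same atoms and bonds and differ only in configuration as drawn: 1 of 1 stereo elements differ; a double bond is drawn Z in compound 2 and E in compound 3. The measured step does not involve a change of configuration, so it bears only indirectly, as a sign of how much this series moved with one modest edit. Among the compounds with values here, the data contain no pair of double-bond isomers, and the direction of any shift remains uncertain. Only a small weakening is expected, with a wide margin on either side. The expected change is a 1.2-fold higher number from compound 2 to compound 3 (0.08 log units; within the scatter). For compound 3, the estimated value is 15000 nM, with an expected range from 5000 nM to 45000 nM.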

Compound 3, half-maximal inhibitory concentration: 47000 nM
The estimate for compound 3 lay 3.1-fold (0.50 log units) below the measured number; measured number above the stated range.
By their numbers in this assay, from the lowest: compound 1; then compound 2; then compound 3.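

In this assay, the configuration of the double bond alone moves the number: a 3.8-fold higher number from compound 2 to compound 3 (0.58 log units; beyond the scatter), so the Z form is the stronger inhibitor of this pair. The earlier step showed only that this series responds to a methoxy group on the aromatic core, whereas this one shows that it also responds with no atom or bond changed, by a step that carries the same modest grade. The shift can be assigned to the double bond geometry on a single ground: the fact that compounds 2 and 3 differ only in the configuration as drawn

The compounds shown leave open whether the preference for the Z form also holds without the methoxy group, as in compound 1, and whether it persists when the trifluoromethyl group gives way to a nitrile or a carboxylic acid. They also leave open whether the double bond itself can be exchanged, for instance for an amide, and what an amine in place of the chlorine would do to the number in this assay.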